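This account rests on a few compounds, and the source may have more. Where it says the series, first, only, none or still open, it means among the compounds named here.

Compound 2 `COc1ccc(F)cc1CNCCCNc1ccnc2cc(C3CCCCC3)ccc12` gives 2290 nM in an ADME assay on HepG2 cells (Homo sapiens) for cytotoxicity, read by luminescence, CellTiter-Glo and ATP content, with a stated time of 72 h (a higher number here means that more compound is needed for the effect, a lower number that less compound is needed), the lowest of the three numbers recorded there. Its nearest neighbour is compound 3 `c1coc(CNCCCNc2ccnc3cc(C4CCCCC4)ccc23)c1`, which gives 4760 nM in this assay, and the furthest is compound 1 `COc1ccccc1Oc1ccc2c(NCCCNCc3ccco3)ccnc2c1`, which gives 6500 nM. Compound 4 `COc1ccc(F)cc1CNCCCNc1ccnc2cc(CC3CCCCC3)ccc12` has not yet been measured; it differs from compound 2 in one place: cyclohexylmethyl in place of cyclohexyl on an aromatic carbon.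

Among the measured compounds shown here, only one recorded step touches the same aromatic carbon: a 1.4-fold lower number from compound 1 to compound 3 (0.14 log units; within the scatter). That step swapped a much larger group for the cyclohexyl and still stayed within the scatter, so the carbon tolerates sizeable changes. The other step, a 2.1-fold higher number from compound 2 to compound 3 (0.32 log units; beyond the scatter), concerns a different position and bears little on the question. Compound 4 keeps the rest of compound 2 unchanged, and extending the cyclohexyl to cyclohexylmethyl is a small change on a position that has shown little sensitivity, so no step beyond the scatter is expected: a 1.1-fold higher number from compound 2 to compound 4 (0.04 log units; within the scatter). Compound 4 is therefore estimated at 2500 nM, with a range from 1100 nM to 5600 nM.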

Compound 4, half-maximal effective concentration: 1830 nM
The estimate for compound 4 lay 1.4-fold (0.14 log units) above the measured number, and the stated range covers the measured number.
By their numbers in this assay, from the lowest: compounds 4 and 2 (each within the scatter of the next); then compounds 3 and 1 (each within the scatter of the next).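

The step of a 1.3-fold lower number from compound 2 to compound 4 (0.10 log units; within the scatter) in this assay shows that going from cyclohexyl to cyclohexylmethyl on this aromatic carbon leaves the number within the scatter. The earlier step at this carbon, a 1.4-fold lower number from compound 1 to compound 3 (0.14 log units; within the scatter), was read with the side chain of compound 3; this one extends that tolerance to the side chain of compound 2 and to a small change, from 6 heavy atoms to 7, with the six-membered ring of carbon kept. No measurement at hand offers an explanation for this flat result.

Going by these compounds, both groups compared here are of carbon only, with no hydrogen-bond donors or acceptors, so it remains open whether an amine or a carboxylic acid on this carbon would behave alike. A longer chain carrying the cyclohexyl ring also remains untested among these compounds.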